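Shortening the diethylamino chain: cytotoxicity notes on compound 3

The compounds below may be only part of what the source reports. "The series", "measured", "known", "first", "only" and "open" are said of these compounds alone.

The series shares one core carrying an aromatic amine with a diethylamino side chain. Compound 1 `CCOC(=O)Nc1cc(NC(C)CCCN(CC)CC)c2nc(-c3cccs3)c(-c3cccs3)nc2n1` sits at a limit of the assay rather than at a number: in an ADME assay on Vero cells (Chlorocebus sabaeus) for cytotoxicity, read by CellTiter-Glo, with a stated time of 72 h (on this read-out higher numbers stand for lower toxicity in this test and lower numbers for higher toxicity in this test), compound 1 gives > 40000 nM, which is the limit of > 40000 nM in this assay, at which 1 of the 2 values shown sits. Among the compounds with values here, compound 2 `CCOC(=O)Nc1cc(NCCCCN(CC)CC)c2nc(-c3ccccc3)c(-c3ccccc3)nc2n1` is the only member with a measured number, giving 1800 nM in this assay; it therefore stands as the sole numerical anchor. Within the data shown here, no step between two measured compounds is available, so the size of a chain change is not yet known from this set.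

Compound 3 `CCOC(=O)Nc1cc(NCCN(CC)CC)c2nc(-c3ccccc3)c(-c3ccccc3)nc2n1` has not been measured. It differs from compound 2 by diethylamino in place of 2-(diethylamino)ethyl on a saturated chain carbon, two bonds along the chain from a nitrogen on an aromatic ring. Among the measured compounds shown here, with no measured step to lean on, the expectation for this assay is a modest move, if any, toward lower toxicity, with a shift that may not exceed the usual scatter. The step from compound 2 to compound 3 is estimated as a 1.7-fold higher number from compound 2 to compound 3 (0.22 log units; within the scatter). Compound 3 is expected to give 3000 nM in this assay, in the range 1000 nM to 12000 nM.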

Compound 3, half-maximal cytotoxic concentration: 2700 nM
Compound 3: middle estimate off by 1.1-fold (0.05 log units), on the high side; the range from low to high includes it.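

In this assay, diethylamino in place of 2-(diethylamino)ethyl on a saturated chain carbon, two bonds along the chain from a nitrogen on an aromatic ring, gives a 1.5-fold higher number from compound 2 to compound 3 (0.18 log units; within the scatter). Within the data shown here, this is the first measured step, and it shows that at this position the chain can be shortened from 4-(diethylamino)butyl to 2-(diethylamino)ethyl with the two compounds remaining indistinguishable in this test. Nothing measured here bears on why the read-out responds to this change as it does.

Compound 1 remains at a limit of the assay, > 40000 nM, and it differs from compound 2 in more than one place, so it gives no readable step for the chain or for any other part of the structure. Still open, going by these compounds, is whether a longer chain than 4-(diethylamino)butyl, or a piperidine in place of the diethylamino group, would move the number in this assay beyond the usual scatter.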